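Methoxy in Place of Methyl on Two Related Cores

The source may report more compounds than this note shows. Statements on the series, on what has been measured and on what is new or still open speak of the compounds shown alone.

Compound 1, `Cc1ccc(-c2n[nH]c(-c3ccccc3)n2)c(C)c1`: in a functional assay on the whole organism (Cricetulus griseus) with Cricetinae gen. sp. as the target (a higher number here means that more compound is needed for the effect, a lower number that less compound is needed), compound 1 gives 0.2 mg/kg.
Compound 2, `COc1ccc(-c2n[nH]c(-c3ccccc3)n2)c(C)c1`: in this assay compound 2 reaches only > 10 mg/kg, which is a limit of the assay and not a number.
Compound 3, `COc1cccc(-c2n[nH]c(-c3cc(C)ccc3C)n2)c1`: in this assay compound 3 gives 2.5 mg/kg.

Compound 1 has a lower number than compound 3, beyond the scatter; the difference between the two cores is not broken down here. For the measured compounds named here, the one measured step is methoxy in place of methyl on an aromatic carbon, which produced an at least 50-fold higher number from compound 1 to compound 2 (1.69 log units; beyond the scatter), and the step is open-ended because of the limit of > 10 mg/kg in this assay, at which 1 of the 3 values shown sits.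

Compound 4, `COc1cccc(-c2n[nH]c(-c3cc(OC)ccc3C)n2)c1`, differs from compound 3 by methoxy in place of methyl on an aromatic carbon. This is the same kind of change as that from compound 1 to compound 2, though not the same: there the place was meta to a methyl group and para to a large group, here it is meta to a large group and para to a methyl group. Resting on an at least 50-fold higher number from compound 1 to compound 2 (1.69 log units; beyond the scatter), a large rise is expected, a 16-fold higher number from compound 3 to compound 4 (1.20 log units; beyond the scatter). Compound 4 is therefore estimated at 40 mg/kg, between 5 mg/kg and 300 mg/kg, most likely again reported only as a limit.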

Compound 4, dose for half-maximal effect: 1 mg/kg
The estimate for compound 4 lay 40-fold (1.60 log units) above the measured number, and the stated range ends above it.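

In this assay, methoxy in place of methyl on an aromatic carbon gave a 2.5-fold lower number from compound 3 to compound 4 (0.40 log units; beyond the scatter), so on this core the change did not bring the large rise seen on the core of compound 1. The two steps point in opposite directions and clearly disagree: the same change on two cores in this assay, an at least 50-fold higher number (1.69 log units; beyond the scatter) from compound 1 to compound 2 and a 2.5-fold lower number (0.40 log units; beyond the scatter) from compound 3 to compound 4, at least 120-fold (2.09 log units) apart, beyond the scatter of two such steps This shows that neither the direction nor the size of the change carried over between these two cores, but it does not show why, and the earlier step has no exact size, resting on a value that is a limit of the assay and not a number: the limit of > 10 mg/kg in this assay, at which 1 of the 4 values shown sits.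

The compounds shown leave open whether the outcome follows the core or the place of the change, as the two pairs differ in both. They also leave open how an amine, a carboxylic acid or a longer chain at these places would behave in this assay.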